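A few compounds are considered here, and "the series" means these few. Any claim that something is new, unique, unknown or untested is made for them only; others in the source may bear on it.

Measured so far in a functional assay on K562 cells (Homo sapiens) for antiproliferative activity, read by MTT assay, with a stated time of 72 h; on this read-out lower numbers stand for stronger inhibition and higher numbers for weaker inhibition:
- compound 1 `C/C=C1/[C@H](O[C@@H]2O[C@H](CO)[C@@H](O)[C@H](O)[C@H]2O)OC=C(C(=O)OC)[C@H]1CC(=O)OCCC1CCCCC1`: 850 nM
- compound 2 `C/C=C1/[C@H](O[C@@H]2O[C@H](CO)[C@@H](O)[C@H](O)[C@H]2O)OC=C(C(=O)OC)[C@H]1CC(=O)OCCC(C)C`: 18000 nM

Compound 2 has the higher of the two numbers, at 18000 nM, and its gap to compound 1 lies beyond the scatter. The next compound is compound 3 `C/C=C1/[C@H](O[C@@H]2O[C@H](CO)[C@@H](O)[C@H](O)[C@H]2O)OC=C(C(=O)OC)[C@H]1CC(=O)OCCc1ccccc1`, which has phenyl in place of isopropyl on a saturated chain carbon, two bonds along the chain from an oxygen next to a carbonyl group. Read one bond further out, this is isopentyl to phenethyl.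

Among the measured compounds shown here, one measured step bears on this change: a 21-fold higher number from compound 1 to compound 2 (1.33 log units; beyond the scatter), a large step at the same place, with isopropyl in place of cyclohexyl. Phenyl, like cyclohexyl, is a six-membered ring, but it is aromatic, and no measurement yet compares the two directly. On the strength of the step of a 21-fold higher number from compound 1 to compound 2 (1.33 log units; beyond the scatter), a lower number is expected in this assay, with only part of that step recovered. The expected change is a 7.2-fold lower number from compound 2 to compound 3 (0.86 log units; beyond the scatter), beyond the scatter. For compound 3 the estimated value is 2500 nM, with an expected range of 600 nM to 10000 nM.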

Compound 3, half-maximal inhibitory concentration: 20000 nM
The estimate for compound 3 lay 8.0-fold (0.90 log units) below the measured number, and the stated range ends below it.
By their numbers in this assay, from the lowest: compound 1; then compounds 2 and 3 (each within the scatter of the next).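

In this assay, phenyl in place of isopropyl on a saturated chain carbon, two bonds along the chain from an oxygen next to a carbonyl group, gives a 1.1-fold higher number from compound 2 to compound 3 (0.05 log units; within the scatter) and so sets isopentyl and phenethyl level at this position. The direct comparison of the two rings, absent from the earlier compounds, is a 24-fold higher number from compound 1 to compound 3 (1.37 log units; beyond the scatter) and is large, so among these three compounds only the cyclohexyl of compound 1 stands apart, and the phenyl of compound 3 goes against any reading that a six-membered ring alone is enough. Nothing at hand accounts for the gap between these two rings.

On these data alone, whether the standing of compound 1 is particular to cyclohexyl or extends to other saturated rings remains open, as cyclopentyl, cycloheptyl and a piperidine ring would test that at the same place. Also open, as far as these compounds go, is how far the cyclohexyl can sit from the oxygen next to the carbonyl group, which a longer chain carrying the same ring would address.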